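Changing the Amide Aryl Group on a Shared Core

A few compounds are considered here, and "the series" means these few. Any claim that something is new, unique, unknown or untested is made for them only; others in the source may bear on it.

compound 1, `CCc1ccccc1C(=O)Nc1ccc2nc(N3CCN(CC)CC3)cc(C)c2c1`: 23900 nM
compound 2, `CCN1CCN(c2cc(C)c3cc(NC(=O)c4ccc(Cl)cc4)ccc3n2)CC1`: 3020 nM
compound 3, `CCN1CCN(c2cc(C)c3cc(NC(=O)c4cc5ccccc5[nH]4)ccc3n2)CC1`: 2550 nM

All three were tested in a functional assay on SK-BR-3 cells (Homo sapiens) for antiproliferative activity, read by MTT assay, with a stated time of 72 h; a higher number here means a weaker inhibitor, a lower number a stronger inhibitor. Compound 3 gives the lowest number of the three, yet its gap to compound 2 is within the scatter, so these two cannot be ranked against each other; compound 1 stands clearly behind both.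

The measured steps are a 7.9-fold lower number from compound 1 to compound 2 (0.90 log units; beyond the scatter), a 9.4-fold lower number from compound 1 to compound 3 (0.97 log units; beyond the scatter) and a 1.2-fold lower number from compound 2 to compound 3 (0.07 log units; within the scatter). The first two show that replacing 2-ethylphenyl with either 4-chlorophenyl or 1H-indol-2-yl gives a clear gain; the third shows that the two favoured groups are interchangeable within the scatter.

Compound 4, `CCN1CCN(c2cc(C)c3cc(NC(=O)c4cccc(C)c4)ccc3n2)CC1`, differs from compound 3 in one place: 3-methylphenyl in place of 1H-indol-2-yl on a carbonyl carbon. The step from compound 2 to compound 3 bears on this, since it shows that a six-membered carbon-only ring can match the 1H-indol-2-yl group in this assay. The step from compound 1 to compound 3 shows that not every such ring does. A small loss is therefore expected, at the edge of the scatter. Compound 4 is expected to give about 5000 nM, within 2000 nM to 14000 nM. The step of a 2.0-fold higher number from compound 3 to compound 4 (0.29 log units; within the scatter) is the expected outcome.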

Compound 4, half-maximal inhibitory concentration: 13700 nM
The estimate for compound 4 lay 2.7-fold (0.44 log units) below the measured number; the range from low to high includes it.
By their numbers in this assay, from the lowest: compounds 3 and 2 (each within the scatter of the next); then compounds 4 and 1 (each within the scatter of the next).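

In this assay, putting 3-methylphenyl in place of 1H-indol-2-yl on the carbonyl carbon brings a clear loss, with a 5.4-fold higher number from compound 3 to compound 4 (0.73 log units; beyond the scatter), and putting it in place of 4-chlorophenyl brings a clear loss too, with a 4.5-fold higher number from compound 2 to compound 4 (0.66 log units; beyond the scatter). A six-membered aromatic ring of carbon only therefore does not settle the outcome at this position: 4-chlorophenyl stays level with 1H-indol-2-yl, whereas 3-methylphenyl sits with 2-ethylphenyl, since a 1.7-fold lower number from compound 1 to compound 4 (0.24 log units; within the scatter) is a gap that cannot be ranked. The substituent on that ring, its place on the ring, or both must matter, but no measurement shown here explains why these groups separate as they do.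

The compounds shown cannot separate the kind of substituent from its place, since the chlorine and the methyl group differ in both; 3-chlorophenyl and 4-methylphenyl would pull these two apart, and plain phenyl would show what either substituent adds. As far as these compounds go, it also remains open how this position responds to a substituent of a different kind, such as an amine or a carboxylic acid on the phenyl ring.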